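Mirror-Image Pair in an Adrenergic Binding Assay

The source may report more compounds than this note shows. Statements on the series, on what has been measured and on what is new or still open speak of the compounds shown alone.

Within the data shown here, compound 1 `N=C(N)NCCCCNC(=O)/C=C/c1ccc2c(c1)[C@@H](C(=O)NCCCCNC(=N)N)[C@@H](c1ccc(O)cc1)O2` is the one member of this set with an actual number: in a binding assay on isolated protein (Salivary gland) for displacement of a labelled ligand from Alpha-1A adrenergic receptor (Rattus norvegicus) (on this read-out higher numbers stand for weaker inhibition and lower numbers for stronger inhibition), compound 1 gives 2440000 nM. Compound 2 `N=C(N)NCCCCNC(=O)[C@@H]1c2cc(/C=C/C(=O)O)ccc2O[C@H]1c1ccc(O)cc1` reaches only a limit of the assay, giving > 100000000 nM. Among the measured compounds shown here, that limit is the point at which the limit of > 100000000 nM in this assay, at which 1 of the 2 values shown sits, sits, so compound 1 stands as the only numerical reading here, and a very weak one. Compound 3 `N=C(N)NCCCCNC(=O)/C=C/c1ccc2c(c1)[C@H](C(=O)NCCCCNC(=N)N)[C@H](c1ccc(O)cc1)O2` is the unmeasured partner. Its relation to compound 1 is a matter of spatial arrangement alone: the two compounds have the same atoms and bonds; at least one stereo element is drawn with a configuration in one of them and without one in the other: 2 of 5 stereo elements differ; a stereocentre at a saturated ring carbon is drawn R in compound 1 and S in compound 3; a stereocentre at a saturated ring carbon is drawn S in compound 1 and R in compound 3. For the measured compounds named here, no measured step of this kind exists in the set, so the size of the effect cannot be read from the data. Because the starting value of compound 1 2440000 nM is already near the edge of what the assay resolves, the expected change is modest and could go either way. Compound 3 is estimated at 3000000 nM, between 500000 nM and 30000000 nM. That estimate corresponds to an expected 1.2-fold higher number from compound 1 to compound 3 (0.09 log units; within the scatter).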

Compound 3, half-maximal inhibitory concentration: 420000 nM
Estimate against measurement, compound 3: 7.1-fold (0.85 log units) above; measured number outside the range, below it.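

Inverting the two stereocentres at the saturated ring carbons, with atoms and bonds unchanged, gives a 5.8-fold lower number from compound 1 to compound 3 (0.76 log units; beyond the scatter) in this assay, so spatial arrangement alone can shift this reading. Among these compounds, this is the first measured step in the set, and it shows a direction: the arrangement drawn in compound 3 gives the stronger inhibition of the pair, although compound 3 at 420000 nM remains a very weak binder. One caution applies to treating this as a clean comparison of two fully defined arrangements: the fact that one of compounds 1 and 3 is drawn with a defined configuration and the other without, at the place where they differ

Among the compounds shown here, compound 2 gives only a limit of the assay, > 100000000 nM, so no step to it can be read. As far as these compounds go, whether the same arrangement still gives the stronger inhibition with a primary amine in place of the guanidine, or with a longer chain, remains open.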